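The source may report more compounds than this note shows. Statements on the series, on what has been measured and on what is new or still open speak of the compounds shown alone.

Measured so far:
- compound 1, `CCCCC[Se]c1nc([Se]CCCCC)c2ccccc2n1`, in a functional assay on MCF7 cells (Homo sapiens) for cytotoxicity, read by MTT assay, with a stated time of 72 h (a higher number here means a weaker inhibitor of growth, a lower number a stronger inhibitor of growth), gives 38400 nM
- compound 2, `Sc1nc(NCc2ccccc2)c2ccccc2n1`, in this assay gives 27200 nM

Compound 2 carries the lower of the two numbers, yet the gap to compound 1 lies within the usual scatter, so the two cannot be told apart on these data. Compound 3, `CCCCC[Se]c1nc(NCc2ccccc2)c2ccccc2n1`, is not yet measured. It differs from compound 2 in one place: a group of 6 heavy atoms (5 carbon, 1 selenium; no ring) in place of one sulfur atom, on an aromatic carbon. Among the measured compounds shown here, with no pair of measured compounds showing the effect of such a change, and with compound 1 already carrying two such chains at 38400 nM, the step from compound 2 to compound 3 is expected to be a 1.1-fold higher number from compound 2 to compound 3 (0.04 log units; within the scatter), that is, none beyond the scatter. Compound 3 is therefore estimated at 30000 nM, within 10000 nM to 90000 nM.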

Compound 3, concentration for 50% growth inhibition: 50 nM
Beside the measured number, compound 3's estimate is 600-fold (2.78 log units) above it; measured number outside the range, below it.
By their numbers in this assay, from the lowest: compound 3; then compounds 2 and 1 (each within the scatter of the next).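

In this assay, the aromatic carbon between two ring nitrogen atoms proves highly sensitive: the group of 6 heavy atoms (5 carbon, 1 selenium) in place of sulfanyl gives a 540-fold lower number from compound 2 to compound 3 (2.74 log units; beyond the scatter) (large). The other substituted aromatic carbon matters as well: the group with one six-membered aromatic ring of carbon only in place of the same selenium chain gives a 770-fold lower number from compound 1 to compound 3 (2.89 log units; beyond the scatter) (large). Nothing shown here accounts for either step.

The compounds shown leave open whether the selenium atom or the five-carbon chain carries the change. A pentylthio group, a shorter or longer chain on selenium, or an amine at this place would separate these.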